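The compounds below may be only part of what the source reports. "The series", "measured", "known", "first", "only" and "open" are said of these compounds alone.

Measured in a functional assay on HeLa cells (Homo sapiens) for antiproliferative activity, read by MTT assay, with a stated time of 48 h (on this read-out lower numbers stand for stronger inhibition and higher numbers for weaker inhibition), so far:
- compound 1 `CC[C@@H](C)[C@H](NC(=O)c1ccc(Oc2nc3ccccc3nc2C)cc1)C(=O)O` gives 33200 nM as a number
- compound 2 `Cc1nc2ccc(Cl)cc2nc1Oc1ccc(C(=O)N[C@@H](CC(C)C)C(=O)O)cc1` gives 16400 nM as a number
- compound 3 `COC(=O)CNC(=O)c1ccc(Oc2nc3ccccc3nc2NC(C)(C)C)cc1` gives > 50000 nM as a limit

Compound 3 stands at > 50000 nM in this assay and this is a limit of the assay, not a number. Compound 4 `CC(C)(C)Nc1nc2ccccc2nc1Oc1ccc(C(=O)NCC(=O)O)cc1` is not yet measured. It differs from compound 3 by hydrogen in place of methyl on an oxygen next to a carbonyl group, which reads as methoxycarbonyl to carboxy.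

Within the data shown here, no measured pair isolates this change, and compound 3 offers no number to step from. The nearest guide is the two compounds that already carry a carboxy group. Compound 1 gives 33200 nM in this assay and compound 2 gives 16400 nM there, though both differ from compound 4 elsewhere as well. On those two values, a modest move towards stronger inhibition is expected, with an estimated step of an at least 1.6-fold lower number from compound 3 to compound 4 (0.22 log units; that floor lies within the scatter) that remains loosely defined. The result could still come back as a limit. The expected value for compound 4 is 30000 nM with 13000 nM to 60000 nM as the range of the estimate.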

Compound 4, half-maximal inhibitory concentration: > 50000 nM
Compound 4 gave a limit, no number; the forecaster's own chance of this, stated with the estimate: 30%; middle value at least 1.6-fold (0.22 log units) away from the limit.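

Compound 3 and compound 4 both stand at a limit of the assay rather than a number, so no step can be read between them: the limit of > 50000 nM in this assay, at which 2 of the 4 values shown sit.

The compounds shown leave open whether the change from methoxycarbonyl to carboxy shifts the read-out in this assay at all.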